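Chloro for Trifluoromethyl: What Compound 4 Should Show

The source may report more compounds than this note shows. Statements on the series, on what has been measured and on what is new or still open speak of the compounds shown alone.

Measured compounds in a functional assay on RAW264.7 cells (Mus musculus) for inhibition; on this read-out lower numbers stand for stronger inhibition and higher numbers for weaker inhibition:
compound 1, `O=C1/C(=C/c2ccccc2Br)CCc2c(O)cccc21`: 1240 nM
compound 2, `O=C1/C(=C/c2ccccc2)CCc2ccc(O)cc21`: 710 nM
compound 3, `O=C1/C(=C/c2ccccc2C(F)(F)F)CCc2ccc(O)cc21`: 1020 nM

Compound 3 stands second highest of the three numbers in this assay. Its nearest neighbour is compound 1, and the two values lie within the scatter of each other; compound 2 is furthest from it, yet a 1.4-fold higher number from compound 2 to compound 3 (0.16 log units; within the scatter) is also within the scatter. Compound 1 carries a bromo group on the same ring but a different placing of the hydroxyl on the core, so its value and that of compound 3 are simply two numbers close together.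

Compound 4, `O=C1/C(=C/c2ccccc2Cl)CCc2ccc(O)cc21`, differs from compound 3 by chloro in place of trifluoromethyl on an aromatic carbon. Among the compounds with values here, the one measured step that bears on this place, a 1.4-fold higher number from compound 2 to compound 3 (0.16 log units; within the scatter), was small, and compound 1 with a halogen there sits close to compound 3 as well. A halogen of modest size in place of trifluoromethyl is therefore expected to move the number little, if at all: a 1.1-fold lower number from compound 3 to compound 4 (0.05 log units; within the scatter). Compound 4 is estimated at 900 nM, with a range from 400 nM to 2000 nM.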

Compound 4, half-maximal inhibitory concentration: 270 nM
Compound 4: middle estimate off by 3.3-fold (0.52 log units), on the high side; measured number outside the range, below it.
By their numbers in this assay, from the lowest: compound 4; then compounds 2, 3 and 1 (each within the scatter of the next).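

In this assay, the position on an aromatic carbon ortho to a large group proves sensitive to which group it carries, as chloro in place of trifluoromethyl produces a change beyond the scatter (a 3.8-fold lower number from compound 3 to compound 4 (0.58 log units; beyond the scatter)). Chloro in place of hydrogen also goes beyond the scatter (a 2.6-fold lower number from compound 2 to compound 4 (0.42 log units; beyond the scatter)), whereas trifluoromethyl in place of hydrogen had stayed within it (a 1.4-fold higher number from compound 2 to compound 3 (0.16 log units; within the scatter)), so the effect at this position depends on the group and is not shared by every replacement of hydrogen. Nothing in the available data explains the difference between chloro and trifluoromethyl.

From the compounds shown here alone, whether a methoxy group, an amine or a carboxylic acid at this position would give a lower or higher number remains open. Going by these compounds, the effect of bromo on this core also remains open, since compound 1 differs from compound 4 in two places.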